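From Compound 2 to Compound 4 in the Cell Assay

This account rests on a few compounds, and the source may have more. Where it says the series, first, only, none or still open, it means among the compounds named here.

Measured so far:
compound 1 `CN(C)Cc1cccc(/C=N/Nc2ncnc3sc(C(C)(C)C)cc23)n1`: 0.419 ug/mL
compound 2 `CN(C)S(=O)(=O)c1ccc(/C=N/Nc2ncnc3sc(C(C)(C)C)cc23)cc1`: 1.42 ug/mL
compound 3 `CN1Cc2ccc(/C=N/Nc3ncnc4sc(C(C)(C)C)cc34)cc2C1`: 0.088 ug/mL

Of the compounds shown here, three sharing one core have been tested in a functional assay on HCT-116 cells (Homo sapiens) for cytotoxicity, read by MTT assay, with a stated time of 3 days; on this read-out higher numbers stand for weaker inhibition and lower numbers for stronger inhibition. Compound 1 gives 0.419 ug/mL, compound 3 gives 0.088 ug/mL, and compound 2 gives 1.42 ug/mL. Compound 2 stands at the highest number of the three: compound 1 sits at a lower number by a margin beyond the scatter, and compound 3 sits at a still lower number, also beyond the scatter. Compound 2 is therefore the weakest inhibitor among the three measured.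

Compound 4 `CC(C)(C)c1cc2c(N/N=C/c3ccc(C(=O)O)cc3)ncnc2s1` has not yet been measured. It differs from compound 2 in one place: carboxy in place of dimethylsulfamoyl on an aromatic carbon. For the measured compounds named here, no measured pair shows this change, so its size is unknown here. The step from compound 2 to compound 4 in this assay is expected to be modest, towards a higher number, though a result within the scatter would not surprise; that expectation is written as a 2.5-fold higher number from compound 2 to compound 4 (0.39 log units; beyond the scatter). Compound 4 is accordingly estimated at 3.5 ug/mL, with a range from 1.2 ug/mL to 10 ug/mL.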

Compound 4, half-maximal inhibitory concentration: 9.99 ug/mL
Beside the measured number, compound 4's estimate is 2.9-fold (0.46 log units) below it; measured number inside the range.
By their numbers in this assay, from the lowest: compound 3; then compound 1; then compound 2; then compound 4.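

In this assay, for the compounds shown here, a 7.0-fold higher number from compound 2 to compound 4 (0.85 log units; beyond the scatter) is the only step here that can be read at a single place, the aromatic carbon para to a large group. It shows that this position is not indifferent to what it carries: carboxy in place of dimethylsulfamoyl, a group of fewer heavy atoms that brings a hydrogen-bond donor, goes with weaker inhibition. Nothing measured here bears on the cause of this step.

This single step does not tell whether the loss of dimethylsulfamoyl or the arrival of carboxy accounts for the change. On these data alone, how a methyl ester or a primary amide on the same aromatic carbon would stand against compound 2 and compound 4 in this assay also remains open.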